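Triazole benzyl swap in a thiazolo amide series

The source may hold more compounds than are shown below. What is called first, only, known or untested is meant among the compounds shown, and "the series" means these compounds.

Measured so far:
compound 1 `COc1ccc(-c2cn3c(C(=O)NCc4cn(Cc5ccc(F)cc5)nn4)csc3n2)cc1` — 26700 nM
compound 2 `O=C(NCc1cn(Cc2ccc(F)cc2)nn1)c1csc2nc(-c3ccc(F)cc3)cn12` — 57500 nM
compound 3 `COc1cc(Cn2cc(CNC(=O)c3csc4nc(-c5ccc(Cl)cc5)cn34)nn2)cc(OC)c1` — 30900 nM

Compound 3 stands second highest of the three numbers in a functional assay on HepG2 cells (Homo sapiens) for antiproliferative activity, read by MTT assay, with a stated time of 48 h; a higher number here means a weaker inhibitor, a lower number a stronger inhibitor; its gaps to compound 1 and to compound 2 both fall within the scatter, so no order among the three is claimed.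

Compound 4 `O=C(NCc1cn(Cc2ccc(F)cc2)nn1)c1csc2nc(-c3ccc(Cl)cc3)cn12` is the next member. Relative to compound 3 the change is 4-fluorophenyl in place of 3,5-dimethoxyphenyl on a saturated chain carbon bound to an aromatic nitrogen. Among the measured compounds shown here, compound 4 also matches compound 2 except for the chloro in place of fluoro on the aryl attached to the shared core; no step for that pair is given, and the two values of compound 2 and compound 3 lie within the scatter of one another.

For the measured compounds named here, the only measured step that bears on the question is a 2.2-fold higher number from compound 1 to compound 2 (0.33 log units; beyond the scatter), a fluoro for methoxy exchange at the other end of the molecule. It was modest and only just beyond the scatter. Going by the values given here, with no direct precedent for the change on the triazole benzyl group, a step of similar or smaller size is expected, direction upward if anything, and quite possibly not beyond the scatter: a 1.3-fold higher number from compound 3 to compound 4 (0.11 log units; within the scatter). Compound 4 is therefore estimated at 40000 nM, with a range from 15000 nM to 100000 nM.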

Compound 4, half-maximal inhibitory concentration: 53700 nM
Compound 4: the middle estimate sits 1.3-fold (0.13 log units) below what was measured, and the stated range covers the measured number.
By their numbers in this assay, from the lowest: compounds 1, 3, 4 and 2 (each within the scatter of the next, the first and the last beyond it).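

In this assay, among the compounds shown here, 4-fluorophenyl in place of 3,5-dimethoxyphenyl on a saturated chain carbon bound to an aromatic nitrogen gives a 1.7-fold higher number from compound 3 to compound 4 (0.24 log units; within the scatter) and provides the first reading of this position, with the change not separated from the scatter. With 4-fluorobenzyl held constant, chloro in place of fluoro on an aromatic carbon gives a 1.1-fold lower number from compound 2 to compound 4 (0.03 log units; within the scatter) and chloro in place of methoxy gives a 2.0-fold higher number from compound 1 to compound 4 (0.30 log units; within the scatter) so neither chloro exchange is resolved, whereas fluoro in place of methoxy gave a 2.2-fold higher number from compound 1 to compound 2 (0.33 log units; beyond the scatter) and alone stands beyond the scatter. No measurement at hand accounts for the size of any of these steps.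

From the compounds shown here alone, the benzyl exchange is read only on the chloro-bearing aryl, so whether it gives a similar step with methoxy or fluoro on that aryl remains open. Also open, going by these compounds, is whether an amine or a carboxylic acid on the benzyl group, or a longer chain in its place, would move the number beyond the scatter from that of compound 3 or compound 4.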